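Replacing an Ethyl Amine with an Amide on the Shared Core

This account rests on a few compounds, and the source may have more. Where it says the series, first, only, none or still open, it means among the compounds named here.

Compound 1 `CN1CCc2nc(C#Cc3cccc(F)c3)sc2C1`: > 10000 nM
Compound 2 `CCN1CCc2nc(C#Cc3ccccc3)sc2C1`: > 10000 nM

In an assay on HEK293 cells for positive allosteric modulation of metabotropic glutamate receptor 5 (Homo sapiens), read by FLIPR, with a stated time of 1 h (a higher number here means that more compound is needed for the effect, a lower number that less compound is needed), compound 2 shows only a limit, > 10000 nM. Compound 1 likewise gives a limit, > 10000 nM, so both measured values sit at the same boundary (the limit of > 10000 nM in this assay, at which 2 of the 2 values shown sit). Compound 3 `O=C(C1CC12CCC2)N1CCc2nc(C#Cc3ccccc3)sc2C1` differs from compound 2 at the ring amine: a group of 8 heavy atoms (7 carbon, 1 oxygen; one three-membered non-aromatic ring of carbon only, one four-membered non-aromatic ring of carbon only) in place of a group of 2 heavy atoms (2 carbon; no ring), on an amine nitrogen in a ring. Among the compounds with values here, no measured step is available to guide the size of this change, so the expectation is a loose one. Compound 3 is expected to come in at about 2500 nM, within 300 nM to 15000 nM, a step of an at least 4.0-fold lower number from compound 2 to compound 3 (0.60 log units; beyond the scatter) that is estimated rather than known.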

Compound 3, half-maximal effective concentration: 3.9 nM
For compound 3 the middle estimate is 640-fold (2.81 log units) above the measured one; measured number below the stated range.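

Within the data shown here, the amine nitrogen in a ring turns out to be a position where a single change decides whether a measurable effect appears at all, a point the earlier compounds could not show. Putting the new amide group in place of ethyl gives an at least 2500-fold lower number from compound 2 to compound 3 (3.40 log units; beyond the scatter). That size is a lower bound only, because the value of compound 2 is a limit: the limit of > 10000 nM in this assay, at which 2 of the 3 values shown sit.

From the compounds shown here alone, the carbonyl and the two carbon rings enter together, so their shares in the gain stay open. An acetyl group on this nitrogen, carrying the carbonyl without the rings, would begin to separate them.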